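The source may report more compounds than this note shows. Statements on the series, on what has been measured and on what is new or still open speak of the compounds shown alone.

Of the compounds shown here, two have so far been measured in an assay on membranes from brain (Cavia porcellus) for binding affinity to Sigma non-opioid intracellular receptor 1 (Homo sapiens); on this read-out lower numbers stand for stronger inhibition and higher numbers for weaker inhibition. Compound 1 `N=C(Nc1cccc2c1CCCC2)Nc1cccc2c1CCCC2` gives 58.8 nM. Compound 2 `Cc1ccccc1/N=C(/N)Nc1cccc(O)c1` gives 207 nM, the higher of the two numbers, and its gap to compound 1 is beyond the usual scatter of such measurements. Compound 3 `Cc1cc([N+](=O)[O-])ccc1/N=C(/N)Nc1cccc(O)c1` has not yet been measured. It differs from compound 2 by nitro in place of hydrogen on an aromatic carbon, meta to a methyl group and para to a large group. Within the data shown here, no measured pair shows this change, so the expected step of a 1.2-fold higher number from compound 2 to compound 3 (0.08 log units; within the scatter) is small, not beyond the scatter in either direction. Compound 3 is therefore expected to give about 250 nM, between 80 nM and 800 nM.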

Compound 3, half-maximal inhibitory concentration: 118 nM
The estimate for compound 3 lay 2.1-fold (0.33 log units) above the measured number, and the stated range covers the measured number.
By their numbers in this assay, from the lowest: compounds 1, 3 and 2 (each within the scatter of the next, the first and the last beyond it).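

In this assay, placing nitro on the aromatic carbon meta to a methyl group and para to a large group gives a 1.8-fold lower number from compound 2 to compound 3 (0.24 log units; within the scatter) and thus no step beyond the usual scatter. Among these compounds, this is the first measured pair to test this position, and it shows that the carbon can carry nitro, with its 3 heavy atoms, in place of hydrogen without a clear shift in the read-out.

From the compounds shown here alone, whether an amine or a carboxylic acid on this same carbon would give a step beyond the scatter remains open. The reason for this result also remains open, as no measurement here speaks to it.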